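This account rests on a few compounds, and the source may have more. Where it says the series, first, only, none or still open, it means among the compounds named here.

In an ADME assay on HEK293-A cells (Homo sapiens) for cytotoxicity, read by MTT assay, with a stated time of 48 h (a lower number here means a stronger inhibitor, a higher number a weaker inhibitor), compound 2 `COC[C@H]1CN(c2ccc(-n3cc(-c4ccccn4)cn3)c(F)c2)C(=O)O1` reports only a limit of the assay, > 400 ug/mL. Compound 1 `CN1CCN(C[C@H]2CN(c3ccc(-n4cc(-c5ccccn5)cn4)c(F)c3)C(=O)O2)CC1` gives 70 ug/mL and compound 3 `CCC(=O)NC[C@H]1CN(c2ccc(-n3cc(-c4ccccn4)cn3)c(F)c2)C(=O)O1` gives 389 ug/mL. The step of an at least 5.7-fold higher number from compound 1 to compound 2 (0.75 log units; beyond the scatter) and the step of a 5.6-fold higher number from compound 1 to compound 3 (0.74 log units; beyond the scatter) are both beyond the scatter, while the step of an at least 1.0-fold lower number from compound 2 to compound 3 (0.01 log units; that floor lies within the scatter) stays within it. Among the compounds with values here, compound 4 `NC(=O)[C@H]1CN(c2ccc(-n3cc(-c4ccccn4)cn3)c(F)c2)C(=O)O1` carries a different kind of change, (carbamoyl in place of methoxymethyl on a saturated ring carbon), on a saturated ring carbon; no measured step touches that place, and the closest guide is the exchange of one group for another between compound 2 and compound 3, which moved nothing beyond the scatter. Compound 4 is therefore expected to give 400 ug/mL, within 200 ug/mL to 800 ug/mL, a step of a number no higher from compound 2 to compound 4 (the limit leaves the size open) that lies within the scatter.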

Compound 4, half-maximal inhibitory concentration: 152 ug/mL
Compound 4: middle estimate off by 2.6-fold (0.42 log units), on the high side; measured number outside the range, below it.
By their numbers in this assay, from the lowest: compound 1; then compound 4; then compound 3. At a limit, above all of these: compound 2.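

In this assay, a change on the saturated ring carbon next to the ring oxygen now moves the number beyond the scatter, unlike the earlier exchange between methoxymethyl and (propanoylamino)methyl: a 2.6-fold lower number from compound 3 to compound 4 (0.41 log units; beyond the scatter) and an at least 2.6-fold lower number from compound 2 to compound 4 (0.42 log units; beyond the scatter). Compound 2 reports only a limit of the assay: the limit of > 400 ug/mL in this assay, at which 1 of the 4 values shown sits. Carbamoyl does not close the gap to (4-methylpiperazin-1-yl)methyl, with a 2.2-fold higher number from compound 1 to compound 4 (0.34 log units; beyond the scatter).

The compounds shown leave open whether an amine or a carboxylic acid on this ring carbon would give a lower number. They also leave open whether a longer chain ending in carbamoyl would keep this step.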